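A few compounds are considered here, and "the series" means these few. Any claim that something is new, unique, unknown or untested is made for them only; others in the source may bear on it.

Working notes on the series. Of the compounds shown here, two have been measured. Compound 1 `CCOc1ccc(-c2cccc(C)c2)cc1` gives 54% in an assay on COS-7 cells for inhibition of patatin-like phospholipase domain-containing protein 2 (Mus musculus), tested at 200 uM; a higher number here means more inhibition at the concentration tested (going by the name of the read-out), a lower number less inhibition. Compound 2 `CCCCCCOC(=O)c1cccc(-c2ccc(OCC)cc2)c1` gives 48% in this assay. The two numbers sit within the scatter of each other, so compound 2 cannot be told apart from compound 1 on what is known; no further comparison is available.

The next compound, compound 3 `CCOc1ccc(-c2cccc(C(=O)N3CCCC3)c2)cc1`, differs from compound 2 in one place: pyrrolidin-1-yl in place of hexyloxy on a carbonyl carbon. For the measured compounds named here, no measured pair shows the effect of exchanging an ester for an amide here, so the size of the step has no precedent.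

The expected step from compound 2 to compound 3 in this assay is a number 3 percentage points lower from compound 2 to compound 3 (within the scatter), that is, no change beyond the scatter. On that basis compound 3 is estimated at 45%, with a range from 25% to 65%.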

Compound 3, a percentage reported as inhibition, at one concentration (the size of the read-out at that concentration, not a potency): 53%
For compound 3 the middle estimate is 8 percentage points below the measured one; measured number inside the range.
By their numbers in this assay, from the lowest: compounds 2, 3 and 1 (each within the scatter of the next).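

The exchange of hexyloxy for pyrrolidin-1-yl on the carbonyl carbon gives a number 5 percentage points higher from compound 2 to compound 3 (within the scatter) in this assay and so shows that, at this position, the ester and the amide cannot be told apart. The larger change, (pyrrolidin-1-yl)carbonyl in place of methyl on the aromatic carbon, gives a number 1 percentage points lower from compound 1 to compound 3 (within the scatter) and likewise moves the read-out no further than the scatter, so neither substituent on this carbon can yet be said to matter. Nothing measured bears on why these steps are so small.

Still open, on these data alone, is whether a carboxylic acid, a morpholine amide or a chain longer than hexyloxy on this carbonyl carbon would shift the number beyond the scatter. As far as these compounds go, with all three compounds read at a single concentration, how their potencies compare also remains open.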